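Urea aryl swap: from halogenated ring to methylphenyl

The source may report more compounds than this note shows. Statements on the series, on what has been measured and on what is new or still open speak of the compounds shown alone.

Compound 3 `O=C(Nc1cccc(CNc2nccnc2Cl)c1)Nc1ccc(F)c(Cl)c1` is one of three aryl ureas built on a shared core. In a functional assay on T-24 cells (Homo sapiens) for antiproliferative activity, read by MTT assay, with a stated time of 48 h (on this read-out lower numbers stand for stronger inhibition and higher numbers for weaker inhibition), compound 3 gives 4990 nM, the lowest of the three numbers. Compound 1 `CCOc1ccc(NC(=O)Nc2cccc(CNc3nccnc3Cl)c2)cc1` gives 9080 nM in this assay, and compound 2 `COc1ccccc1NC(=O)Nc1cccc(CNc2nccnc2Cl)c1` gives 10400 nM. The measured steps are a 1.1-fold higher number from compound 1 to compound 2 (0.06 log units; within the scatter), a 1.8-fold lower number from compound 1 to compound 3 (0.26 log units; within the scatter) and a 2.1-fold lower number from compound 2 to compound 3 (0.32 log units; beyond the scatter).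

Compound 4 `Cc1ccc(NC(=O)Nc2cccc(CNc3nccnc3Cl)c2)cc1` differs from compound 3 in a single place: 4-methylphenyl in place of 3-chloro-4-fluorophenyl on an amide-type nitrogen. The two steps that bear on this change both run from an ether-bearing ring, 4-ethoxyphenyl or 2-methoxyphenyl, to the 3-chloro-4-fluorophenyl, and each lowered the number only modestly. Among the measured compounds shown here, compound 4 carries a 4-methylphenyl, which none of the measured compounds shows, so the expectation rests on the small spread seen so far. Compound 4 is therefore expected to show a step of a 1.6-fold higher number from compound 3 to compound 4 (0.20 log units; within the scatter), a mild rise back toward the numbers of the ether-bearing analogues. The estimate for compound 4 is 8000 nM, with a range from 4000 nM to 16000 nM.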

Compound 4, half-maximal inhibitory concentration: 9820 nM
Compound 4: the middle estimate sits 1.2-fold (0.09 log units) below what was measured; the measured number falls inside the stated range.
By their numbers in this assay, from the lowest: compounds 3, 1, 4 and 2 (each within the scatter of the next, the first and the last beyond it).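

In this assay the change to the 4-methylphenyl on this amide-type nitrogen gives a 2.0-fold higher number from compound 3 to compound 4 (0.29 log units; within the scatter) and so leaves no readable difference from the 3-chloro-4-fluorophenyl. Among the compounds shown here, the new ring also shows no readable difference from the ether-bearing rings, with a 1.1-fold lower number from compound 2 to compound 4 (0.02 log units; within the scatter) and a 1.1-fold higher number from compound 1 to compound 4 (0.03 log units; within the scatter) as the readings, so the only step beyond the scatter in this set remains the one between compound 2 and compound 3. Nothing given here accounts for these steps.

The 3-chloro-4-fluorophenyl is the only halogenated ring shown, so a ring carrying the chlorine alone or the fluorine alone remains open, as does a ring bearing an amine or a carboxylic acid. Going by these compounds, all four compounds keep the shared core unchanged, so the effect of any change there on these numbers stays unknown.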